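A few compounds are considered here, and "the series" means these few. Any claim that something is new, unique, unknown or untested is made for them only; others in the source may bear on it.

Compound 1, `O=C(O)CCCCCCCC#CC#CC#CC#C[C@@H](O)CO`, gives 2.6 ug/mL in a functional assay on KB cells (Homo sapiens) for cytotoxicity; on this read-out higher numbers stand for an effect only at larger amounts of compound and lower numbers for an effect already at smaller amounts. Among the compounds with values here, compound 2, `C[C@H](O)C#CC#CC#CC#CCCCCCCCC(=O)O`, gives 3.7 ug/mL in this assay and stands with the highest of the two numbers, its only neighbour being compound 1 at a 1.4-fold higher number from compound 1 to compound 2 (0.15 log units; within the scatter), a step within the scatter. Compound 3, `C[C@H](O)/C=C/C#CC#CC#CCCCCCCCC(=O)O`, differs from compound 2 by 3-hydroxybut-1-en-1-yl in place of 3-hydroxybut-1-yn-1-yl on a triple-bonded carbon. Within the data shown here, no measured step touches this change; the single step so far, from compound 1 to compound 2, concerned a hydroxy group elsewhere on the chain and stayed within the scatter. For compound 3 no shift beyond the scatter is expected, no change at the digits printed from compound 2 to compound 3 (within the scatter), with an estimate of 3.7 ug/mL in the range 1.5 ug/mL to 9 ug/mL.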

Compound 3, concentration for half-maximal effect: 1.1 ug/mL
For compound 3 the middle estimate is 3.4-fold (0.53 log units) above the measured one, outside the stated range (below it).
By their numbers in this assay, from the lowest: compound 3; then compounds 1 and 2 (each within the scatter of the next).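

In this assay, within the data shown here, 3-hydroxybut-1-en-1-yl in place of 3-hydroxybut-1-yn-1-yl on a triple-bonded carbon gives the first change in this short series that lies beyond the scatter (a 3.4-fold lower number from compound 2 to compound 3 (0.53 log units; beyond the scatter)). The same group in place of 3,4-dihydroxybut-1-yn-1-yl also goes beyond the scatter (a 2.4-fold lower number from compound 1 to compound 3 (0.37 log units; beyond the scatter)), so this position responds to a double bond in place of a triple bond. Nothing available explains the shift.

Going by these compounds, whether an amine in place of the hydroxy group, or a methyl ester in place of the carboxylic acid, moves the number remains open.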